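Aminopyrimidine series: para substituent on the aniline ring

The source may hold more compounds than are shown below. What is called first, only, known or untested is meant among the compounds shown, and "the series" means these compounds.

Measured so far:
compound 1 `CCc1nc(N)nc(N)c1-c1ccc(CNc2ccc([N+](=O)[O-])cc2)cc1` — 9.2 nM
compound 2 `CCc1nc(N)nc(N)c1-c1ccc(CNc2ccc(S(C)(=O)=O)cc2)cc1` — 9.8 nM

In an in vitro assay on CHOK cells for displacement of a labelled ligand from growth hormone secretagogue receptor type 1 (Homo sapiens) (on this read-out lower numbers stand for stronger inhibition and higher numbers for weaker inhibition), compound 1 gives 9.2 nM and compound 2 gives 9.8 nM. Compound 2 stands at the higher of the two numbers, but the step of a 1.1-fold higher number from compound 1 to compound 2 (0.03 log units; within the scatter) lies within the scatter, so the two compounds cannot be ordered.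

Compound 3 `CCc1nc(N)nc(N)c1-c1ccc(CNc2ccc(Cl)cc2)cc1` is not yet measured. It differs from compound 2 in one place: chloro in place of methylsulfonyl on an aromatic carbon. Going by the values given here, the only measured step that bears on this position is a 1.1-fold higher number from compound 1 to compound 2 (0.03 log units; within the scatter), a swap of two groups on the same aromatic carbon that left the number unchanged within the scatter. Chloro carries no hydrogen-bond acceptors, whereas both earlier groups did, so the single step gives only a loose guide. The expectation for compound 3 is therefore no step beyond the scatter, a 1.4-fold higher number from compound 2 to compound 3 (0.15 log units; within the scatter), with a wide range on either side. Compound 3 is estimated at 14 nM in this assay, between 4 nM and 60 nM.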

Compound 3, half-maximal inhibitory concentration: 300 nM
Beside the measured number, compound 3's estimate is 21-fold (1.33 log units) below it, outside the stated range (above it).
By their numbers in this assay, from the lowest: compounds 1 and 2 (each within the scatter of the next); then compound 3.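

In this assay this position turns out to be sensitive to the group it carries: chloro in place of methylsulfonyl gives a 31-fold higher number from compound 2 to compound 3 (1.49 log units; beyond the scatter) and chloro in place of nitro gives a 33-fold higher number from compound 1 to compound 3 (1.51 log units; beyond the scatter), both large, whereas the swap between the two earlier groups stayed within the scatter. Across these three compounds, the two groups with hydrogen-bond acceptors share one level and chloro, which has none, stands far from them, though three compounds are too few to tie the loss to that count. Nothing available explains the size of these steps.

The compounds shown leave open whether acceptor count is what separates these groups. A methoxy group, a plain methyl group, an amine or a carboxylic acid at this position would help to test that reading.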